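Sulfanyl versus amino substituents on the shared core

The source may report more compounds than this note shows. Statements on the series, on what has been measured and on what is new or still open speak of the compounds shown alone.

Measured compounds:
compound 1, `CC(C)CSc1nc(N)nc2c1ncn2/C=C1/CC1(CO)CO`: 60000 nM
compound 2, `CCCNc1nc(N)nc2c1ncn2/C=C1/CC1(CO)CO`: > 20000 nM
compound 3, `CCCCNc1nc(N)nc2c1ncn2/C=C1/CC1(CO)CO`: > 20000 nM

In an ADME assay on CCRF-HSB-2 cells (Homo sapiens) for cytotoxicity, with a stated time of 7 days (on this read-out lower numbers stand for higher toxicity in this test and higher numbers for lower toxicity in this test), compound 1 gives 60000 nM. For compound 2 the value > 20000 nM is a limit of the assay, not a number. For compound 3 the value > 20000 nM is likewise a limit, so compound 3 stands at the limit of > 20000 nM in this assay, at which 2 of the 3 values shown sit. Compound 4, `CCCCCCSc1nc(N)nc2c1ncn2/C=C1/CC1(CO)CO`, carries the change (hexylsulfanyl in place of butylamino on an aromatic carbon). The steps a step that the limit leaves unreadable from compound 1 to compound 3 and a step that the two limits leave unreadable from compound 2 to compound 3 concern the same aromatic carbon but are unreadable, and a step that the limit leaves unreadable from compound 1 to compound 2 is unreadable as well. No readable step bears on this change, so no direction can be read for it in this assay; compound 4 is expected to stay in the same weakly toxic region, with an expected step that the limit leaves unreadable from compound 3 to compound 4. Compound 4 is estimated at 40000 nM, between 10000 nM and 150000 nM.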

Compound 4, half-maximal cytotoxic concentration: 60000 nM
Compound 4: the middle estimate sits 1.5-fold (0.18 log units) below what was measured; low and high end bracket the measured number.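

Among the compounds shown here, the first readable comparison at this aromatic carbon in this assay stays among the sulfanyl compounds: pentyl in place of isopropyl on a saturated chain carbon bound to a sulfur gives no change at the digits printed from compound 1 to compound 4 (within the scatter). Between these two sulfanyl chains, the read-out therefore does not separate the isobutylsulfanyl and hexylsulfanyl groups. The steps from the two amino compounds to the sulfanyl compounds cannot be read, as compound 2 and compound 3 each stand at a limit of the assay, not a number.

On these data alone, whether swapping sulfur for nitrogen at this carbon shifts the read-out stays open. So does what a benzylsulfanyl group or a longer chain such as decylsulfanyl would give there.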